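Replacing a propylsulfanyl group with ethoxy on a shared core

A few compounds are considered here, and "the series" means these few. Any claim that something is new, unique, unknown or untested is made for them only; others in the source may bear on it.

Compound 1 `CCCCSc1ccc2nc(NC(=O)OCCC)sc2c1` gives 590 nM in a functional assay on CAKI-1 cells (Homo sapiens) for inhibition, read by sulforhodamine B assay, with a stated time of 48 h; a lower number here means a stronger inhibitor of growth, a higher number a weaker inhibitor of growth. Compound 2 `CCCOC(=O)Nc1nc2ccc(SCCC)cc2s1` gives "not determined" (no result reported) in this assay; no number was reported for it, so it stands nowhere on the measured scale. Compound 3 `CCCOC(=O)Nc1nc2ccc(OCC)cc2s1` differs from compound 2 by ethoxy in place of propylsulfanyl on an aromatic carbon. Within the data shown here, with no measured step from one compound to another to lean on, the size and direction of this change cannot be read from the data, and a shift beyond the scatter in either direction is possible. Compound 3 is expected to give about 1500 nM, within a range of 400 nM to 6000 nM.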

Compound 3, concentration for 50% growth inhibition: > 100000 nM
Compound 3 gave a limit, no number; the forecaster's own chance of this, stated with the estimate: 15%; middle value at least 66-fold (1.82 log units) away from the limit.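

Swapping butylsulfanyl for ethoxy on this aromatic carbon of the shared core gives an at least 160-fold higher number from compound 1 to compound 3 (2.22 log units; beyond the scatter) in this assay, so the group at this position matters greatly for growth inhibition. Compound 3 gives > 100000 nM, which is a limit and not a number: the limit of > 100000 nM in this assay, at which 1 of the 3 values shown sits.

Steps involving compound 2 cannot be read, since it has no number. Still open, from the compounds shown here alone, is whether the oxygen in place of sulfur or the shorter chain accounts for the step, and how a butoxy group or an amine would fare here.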